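A Small Swap on the Pendant Aromatic Ring

The compounds below may be only part of what the source reports. "The series", "measured", "known", "first", "only" and "open" are said of these compounds alone.

The compounds here were tested in an assay on cells for inhibition of S-adenosylmethionine decarboxylase proenzyme (Homo sapiens), read by mass spectrometry, at pH 7.2; on this read-out lower numbers stand for stronger inhibition and higher numbers for weaker inhibition. Compound 1, with the structure `Nc1ccnc(Nc2cc(Cl)cc(Cl)c2)c1`, is reported in this assay only as a limit, at > 180000 nM. Compound 2, with the structure `Cc1cc(Nc2cc(Cl)cc(Cl)c2O)nc(N)n1`, is likewise reported only as a limit, at > 180000 nM. Compound 3 has the structure `Cc1cc(Nc2cc(Cl)cc(-c3ccc(C(F)(F)F)cc3)c2)nc(N)n1`, and for compound 3 this assay again gives only a limit, at > 21000 nM. So every value shown so far is a limit rather than a number, and compound 3 sits at a limit different from the other two, as the limit of > 180000 nM in this assay, at which 2 of the 3 values shown sit, and the limit of > 21000 nM in this assay, at which 1 of the 3 values shown sits, show; no ranking of the three can be drawn from this.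

Compound 4, not yet measured, has the structure `CC(=O)c1ccc(-c2cc(Cl)cc(Nc3cc(C)nc(N)n3)c2)cc1`. It differs from compound 3 in one place: acetyl in place of trifluoromethyl on an aromatic carbon. Among the measured compounds shown here, no step between measured compounds is available to show what such a change does in this assay. With nothing measured to lean on, the expected change is a step that the limit leaves unreadable from compound 3 to compound 4, nothing beyond the usual scatter. Compound 4 is therefore estimated at 30000 nM in this assay, within a range from 8000 nM to 120000 nM, and most likely reported once more only as a limit.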

Compound 4, half-maximal inhibitory concentration: > 21000 nM
Compound 4 was reported as a limit (the forecaster's own chance of this, stated with the estimate: 70%); the middle value is on the limit's open side.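

Compound 4 is reported in this assay only as a limit, > 21000 nM. Compound 3 is also reported only as a limit, so no step can be read between compound 3 and compound 4. The compounds shown leave open whether acetyl in place of trifluoromethyl changes inhibition at all, and how strongly either compound inhibits.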